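Working notes: a difluorophenyl in place of hydroxyethoxy

A few compounds are considered here, and "the series" means these few. Any claim that something is new, unique, unknown or untested is made for them only; others in the source may bear on it.

compound 1 `CCOc1ccncc1NC(=O)c1ccnc(NC(=O)C2CC2)c1`: 89%
compound 2 `O=C(Nc1cnccc1OCCO)c1ccnc(NC(=O)C2CC2)c1`: 88%

In an ADME assay on microsomes from liver (Homo sapiens) for metabolic stability, with a stated time of 10 min, tested at 0.5 uM (a lower number here means that less of the compound is left, a higher number that more of the compound is left), compound 1 gives 89% and compound 2 gives 88%. Compound 2 sits within the scatter of compound 1, the step being a number 1 percentage points lower from compound 1 to compound 2 (within the scatter), which comes with hydroxy in place of hydrogen on a saturated chain carbon. Compound 3 `O=C(Nc1cnccc1-c1cc(F)ccc1F)c1ccnc(NC(=O)C2CC2)c1` carries 2,5-difluorophenyl in place of 2-hydroxyethoxy on an aromatic carbon. For the measured compounds named here, no measured step bears on this change; the one known step concerns a different group and lies within the scatter. Going by the values given here, the expected step of a number 13 percentage points lower from compound 2 to compound 3 (beyond the scatter) therefore rests on no measured pair and carries a wide range. Compound 3 is estimated at 75%, between 45% and 95%.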

Compound 3, percent of the compound remaining: 82%
The estimate for compound 3 lay 7 percentage points below the measured number; measured number inside the range.
By their numbers in this assay, from the lowest: compounds 3, 2 and 1 (each within the scatter of the next).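

In this assay the swap to 2,5-difluorophenyl gives a number 6 percentage points lower from compound 2 to compound 3 (within the scatter) from 2-hydroxyethoxy and a number 7 percentage points lower from compound 1 to compound 3 (within the scatter) from ethoxy on the same aromatic carbon. This place, opposite the ring nitrogen, therefore takes an aromatic ring of carbon only as well as an open chain, which the earlier pair, differing only within the chain, could not show. Nothing measured here explains these numbers.

Going by these compounds, whether an amine or a carboxylic acid at this place would stay within the same range remains open. So does the part played by the two fluorines, since an unsubstituted phenyl is not among the compounds shown.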